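The compounds below may be only part of what the source reports. "The series", "measured", "known", "first", "only" and "open" are said of these compounds alone.

Of the compounds shown here, two sharing one core have so far been tested in a functional assay on the whole organism (strain Wistar) for inhibition, with Rattus norvegicus as the target, read by paw edema, with a stated time of 1 h, at a dose of 6 mg/kg by the oral route; a lower number here means less inhibition, a higher number more inhibition at the dose given (going by the name of the read-out). Compound 1 `O=C(CO[N+](=O)[O-])NNC(=O)c1ccc(-n2[nH]c(=O)cc2-c2ccccc2O)cc1` gives 23% in this assay. Compound 2 `O=C(CO[N+](=O)[O-])NNC(=O)c1ccc(-n2[nH]c(=O)cc2-c2ccccc2)cc1` gives 19.8% in this assay. The change between them, hydrogen in place of hydroxy on an aromatic carbon, brought a number 3.2 percentage points lower from compound 1 to compound 2 (within the scatter), so on the numbers shown compound 2 and compound 1 cannot be told apart. Compound 3 `CCOC(=O)c1c(-c2ccccc2)n(-c2ccc(C(=O)NNC(=O)CO[N+](=O)[O-])cc2)[nH]c1=O` has not yet been measured. It differs from compound 2 in a single place: ethoxycarbonyl in place of hydrogen on an aromatic carbon. The one measured step concerns a hydroxy, not an ethoxycarbonyl, so no shown step bears directly on this change, and that step itself stayed within the scatter. For compound 3 in this assay the expected step is therefore a number 1.2 percentage points higher from compound 2 to compound 3 (within the scatter), nothing beyond the scatter. Compound 3 is estimated at 21%, with a range from 10% to 33%.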

Compound 3, a percentage reported as inhibition, in the whole organism at one dose (the size of the read-out at that dose, not a potency): 54%
Beside the measured number, compound 3's estimate is 33 percentage points below it; the measured number lies above the stated range.
By their numbers in this assay, from the lowest: compounds 2 and 1 (each within the scatter of the next); then compound 3.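

Compound 2 carries only a hydrogen on this aromatic carbon of the five-membered ring, next to the ring atom that bears a phenyl group, and this proves to be a place where a change can matter. In this assay, among these compounds, ethoxycarbonyl in place of that hydrogen gives a number 34.2 percentage points higher from compound 2 to compound 3 (beyond the scatter), whereas the one earlier step, involving a hydroxy, stayed within the scatter. Nothing shown here explains the size of this step.

With ethoxycarbonyl as the only group shown at this carbon, it remains open whether the gain needs the whole ester or would also appear with a carboxylic acid, a methyl or a longer chain such as butoxycarbonyl. As far as these compounds go, it is also open whether the gain would hold at other doses or times, since all three values come from a single dose and time.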